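Working notes: from compound 3 to compound 4

The source may report more compounds than this note shows. Statements on the series, on what has been measured and on what is new or still open speak of the compounds shown alone.

In a functional assay on OVCAR-8 cells (Homo sapiens) (on this read-out higher numbers stand for weaker inhibition of growth and lower numbers for stronger inhibition of growth), compound 1 (`O=S(=O)(/C=C/c1ccc(Cl)cc1)Cc1ccc(Nc2ncnc3ccccc23)cc1`) gives > 100000 nM, which is a limit. Compound 2 (`O=S(=O)(/C=C/c1ccc(F)cc1F)Cc1ccc(Nc2ncnc3ccccc23)cc1`) gives > 100000 nM, also a limit. Among the measured compounds shown here, compound 3 (`O=S(=O)(/C=C/c1ccc(F)cc1Cl)Cc1ccc(Nc2ncnc3ccccc23)cc1`) gives 100000 nM, the only number in the set. The series thus stands at the limit of > 100000 nM in this assay, at which 2 of the 3 values shown sit.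

The change to compound 4 (`O=S(=O)(/C=C/c1ccc(O)cc1)Cc1ccc(Nc2ncnc3ccccc23)cc1`) is 4-hydroxyphenyl in place of 2-chloro-4-fluorophenyl on a double-bonded chain carbon bound to a double-bonded chain carbon. The measured steps of a number no higher from compound 1 to compound 3 (the limit leaves the size open) and a number no higher from compound 2 to compound 3 (the limit leaves the size open) are open-ended, and a step that the two limits leave unreadable from compound 1 to compound 2 cannot be read, so none gives a size. None of them brings in 4-hydroxyphenyl.

Compound 3 with 100000 nM is the only anchor, so no step beyond the scatter is expected in this assay. The expected step is no change at the digits printed from compound 3 to compound 4 (within the scatter). For compound 4 the estimate is 100000 nM, with an expected range of 30000 nM to 150000 nM.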

Compound 4, concentration for 50% growth inhibition: 1000 nM
The estimate for compound 4 lay 100-fold (2.00 log units) above the measured number, and the stated range ends above it.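

At this place, on a double-bonded chain carbon bound to a double-bonded chain carbon, the group clearly matters in this assay: 4-hydroxyphenyl gives a 100-fold lower number from compound 3 to compound 4 (2.00 log units; beyond the scatter). The same change gives an at least 100-fold lower number from compound 2 to compound 4 (2.00 log units; beyond the scatter), and hydroxy in place of chloro on an aromatic carbon gives an at least 100-fold lower number from compound 1 to compound 4 (2.00 log units; beyond the scatter). These last two steps start from a limit, so their full size stays open: the limit of > 100000 nM in this assay, at which 2 of the 4 values shown sit.

The compounds shown leave open whether the hydroxy group itself is needed, or whether 4-methoxyphenyl or 4-aminophenyl at this place would give a similar step.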